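This account rests on a few compounds, and the source may have more. Where it says the series, first, only, none or still open, it means among the compounds named here.

Of the compounds shown here, three sharing one core have been read in a functional assay on MCF7 cells (Homo sapiens) for antiproliferative activity, read by MTT assay, with a stated time of 48 h; a higher number here means a weaker inhibitor, a lower number a stronger inhibitor. Compound 1 (`CC(=O)N1N=C(c2ccc3ccccc3c2)OC1c1ccccc1Cl`) gives 2.36 ug/mL, and compound 2 (`CC(=O)N1N=C(c2ccc3ccccc3c2)OC1c1ccccc1F`) gives 3.44 ug/mL. Between these two lies a 1.5-fold higher number from compound 1 to compound 2 (0.16 log units; within the scatter). Compound 3 (`CC(=O)N1N=C(c2ccc3ccccc3c2)OC1c1ccccc1[N+](=O)[O-]`) gives 18.2 ug/mL, the highest number of the three, which makes it the weakest inhibitor of the set. It is separated from the others by a 7.7-fold higher number from compound 1 to compound 3 (0.89 log units; beyond the scatter) and by a 5.3-fold higher number from compound 2 to compound 3 (0.72 log units; beyond the scatter).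

The next compound, compound 4 (`CC(=O)N1N=C(c2ccc3ccccc3c2)OC1c1ccsc1`), carries thiophen-3-yl in place of 2-nitrophenyl on a saturated ring carbon, so thiophen-3-yl stands in place of 2-nitrophenyl on a saturated ring carbon. Among the measured compounds shown here, no measured step covers thiophen-3-yl, so the evidence is indirect. Only compound 3 stands apart, and the nitro group leaves with its whole ring. Compound 4 is therefore expected to fall back towards compound 1 and compound 2, though probably not fully, given the unmeasured ring. The expected change is an estimated 3.0-fold lower number from compound 3 to compound 4 (0.48 log units; beyond the scatter), modest in size and towards a lower number. For compound 4 the estimated value is 6 ug/mL, with an expected range of 2 ug/mL to 18 ug/mL.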

Compound 4, half-maximal inhibitory concentration: 7.98 ug/mL
Compound 4: the middle estimate sits 1.3-fold (0.12 log units) below what was measured; low and high end bracket the measured number.
By their numbers in this assay, from the lowest: compounds 1 and 2 (each within the scatter of the next); then compound 4; then compound 3.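

In this assay, the saturated ring carbon also accepts a ring other than a substituted phenyl: thiophen-3-yl, a five-membered aromatic ring with one hetero atom, gives a stronger inhibitor than the 2-nitrophenyl of compound 3 (a 2.3-fold lower number from compound 3 to compound 4 (0.36 log units; beyond the scatter)). It does not match the two halogen-bearing rings, however (a 2.3-fold higher number from compound 2 to compound 4 (0.37 log units; beyond the scatter); a 3.4-fold higher number from compound 1 to compound 4 (0.53 log units; beyond the scatter)), so this single change places compound 4 between the halogen-bearing pair and the nitro compound. Nothing available bears on why the swap lands there.

The compounds shown leave open how much of this result belongs to the thiophene ring and how much to losing the substituted phenyl, as an unsubstituted phenyl would help to separate. They also leave open how a methoxy group or an amine on the phenyl ring would read, and whether a pyridine ring would behave like thiophen-3-yl.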